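Moving the methyl on the piperidine of compound 1

The source may report more compounds than this note shows. Statements on the series, on what has been measured and on what is new or still open speak of the compounds shown alone.

Measured so far in a physicochemical assay for lipophilicity; a higher number here means a more lipophilic compound, a lower number a more polar compound:
- compound 1, `CC1CCCN(Cc2c(-c3nnc(SC(C)C)n3-c3ccccc3)n(C)c3ccccc23)C1`: compound 1 gives 6.03
- compound 2, `COc1ccc(CNCc2c(-c3nnc(SC(C)C)n3-c3ccccc3)n(C)c3ccc(F)cc23)cc1`: compound 2 gives 6.42
- compound 3, `COc1cccc(CNCc2c(-c3nnc(SC(C)C)n3-c3ccccc3)n(C)c3ccc(F)cc23)c1`: compound 3 gives 6.42

Compound 1 stands lowest of the three numbers in this assay. Compound 2 and compound 3 lie together above it, each by a gap beyond the scatter; between compound 2 and compound 3 themselves the step reads no change at the digits printed from compound 2 to compound 3 (within the scatter).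

Compound 4, `CC1CCN(Cc2c(-c3nnc(SC(C)C)n3-c3ccccc3)n(C)c3ccccc23)CC1`, has not yet been measured. It differs from compound 1 in one place: 4-methylpiperidin-1-yl in place of 3-methylpiperidin-1-yl on a saturated chain carbon bound to an aromatic carbon. The two compounds have the same atoms, joined differently.

Within the data shown here, one measured step bears on this: from compound 2 to compound 3 a methoxyphenyl was rearranged without any change in this assay beyond the scatter. The move from compound 1 to compound 4 is of the same kind, a methyl shifted around a ring of the same size and content, so no step beyond the scatter is expected; compound 4 is expected to show no change at the digits printed from compound 1 to compound 4 (within the scatter). Compound 4 is therefore estimated at 6.03, within a range from 5.7 to 6.35.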

Compound 4, partition coefficient: 5.96
Estimate against measurement, compound 4: 0.07 log units above; the measured number falls inside the stated range.
By their numbers in this assay, from the lowest: compounds 4 and 1 (each within the scatter of the next); then compounds 2 and 3 (each within the scatter of the next).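

In this assay the 3-methylpiperidin-1-yl of compound 1 and the 4-methylpiperidin-1-yl of compound 4 occupy the same place, on a saturated chain carbon bound to an aromatic carbon, and the exchange gives a number 0.07 log units lower from compound 1 to compound 4 (within the scatter) at this place. The earlier compounds shown here showed such a rearrangement only for a methoxy group on a phenyl, with no change at the digits printed from compound 2 to compound 3 (within the scatter) as the step, and a methyl moved around a saturated ring now also gives a step within the scatter. No other measurement bears on this result, so it stands without an explanation.

On these data alone, whether 2-methylpiperidin-1-yl would fit the same picture remains open. So does the outcome of replacing the methylpiperidine at this place with morpholin-4-yl or with an open-chain diethylamine.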